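The source may hold more compounds than are shown below. What is called first, only, known or untested is meant among the compounds shown, and "the series" means these compounds.

Three compounds have been measured in a functional assay on the whole organism with Mus musculus as the target, with a stated time of 90 min, at a dose of 25 umol/kg by the oral route; a lower number here means a weaker effect, a higher number a stronger effect of the compound at the dose given:

- compound 1, `O=C(CN(c1nc(Cl)nc2c1ncn2C1CCCCO1)C1CC1)N[C@@H](CCC(=O)OCc1ccccc1)C(=O)OCc1ccccc1`, gives 25.2%
- compound 2, `O=C(CN(c1nc(Cl)nc2c1ncn2C1CCCCO1)C1CC1)NCC(=O)OCc1ccccc1`, gives 25.9%
- compound 3, `CSCC[C@H](NC(=O)CN(c1nc(Cl)nc2c1ncn2C1CCCCO1)C1CC1)C(=O)OCc1ccccc1`, gives 42.7%

Compound 3 stands highest of the three, with compound 2 nearest, the step being a number 16.8 percentage points higher from compound 2 to compound 3 (beyond the scatter), and compound 1 furthest, the step being a number 17.5 percentage points higher from compound 1 to compound 3 (beyond the scatter). Compounds 1 and 2 are within the scatter of each other, as seen in a number 0.7 percentage points higher from compound 1 to compound 2 (within the scatter).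

Compound 4, `CC(C)[C@H](NC(=O)CN(c1nc(Cl)nc2c1ncn2C1CCCCO1)C1CC1)C(=O)OCc1ccccc1`, has not yet been measured. It differs from compound 3 by isopropyl in place of 2-(methylsulfanyl)ethyl on a saturated chain carbon bound to an amide-type nitrogen and a carbonyl carbon. Among the measured compounds shown here, the steps that bear on this are those that vary the same saturated chain carbon: the gain from compound 2 to compound 3 and from compound 1 to compound 3 were both modest and beyond the scatter. For the measured compounds named here, no measured step places isopropyl at this position, so the direction is uncertain; a modest downward step in this assay toward the values of compounds 1 and 2 is expected, though one within the scatter cannot be excluded. The expected step is a number 9.7 percentage points lower from compound 3 to compound 4 (within the scatter). Compound 4 is therefore estimated at 33%, with a range from 18% to 50%.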

Compound 4, a percentage reported as activity, at one dose (the size of the read-out at that dose, not a potency): 30.1%
Compound 4: middle estimate off by 2.9 percentage points, on the high side, within the range that was stated.
By their numbers in this assay, from the lowest: compounds 1, 2 and 4 (each within the scatter of the next); then compound 3.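

At the saturated chain carbon bound to an amide-type nitrogen and a carbonyl carbon, isopropyl in place of 2-(methylsulfanyl)ethyl lowers the effect in this assay (a number 12.6 percentage points lower from compound 3 to compound 4 (beyond the scatter)), so the higher number of compound 3 does not carry over to this branched group. Isopropyl cannot be told apart from hydrogen (a number 4.2 percentage points higher from compound 2 to compound 4 (within the scatter)) or from 2-(benzyloxycarbonyl)ethyl (a number 4.9 percentage points higher from compound 1 to compound 4 (within the scatter)). Among these four compounds, only 2-(methylsulfanyl)ethyl therefore stands apart at this position, and a carbon group here does not by itself raise the number.

An unbranched butyl group at this carbon would show whether the higher number goes with the sulfur atom or with the straight chain. Nothing available explains why these groups differ.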